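Swapping Pyrimidinyl for an Ester in Two Related Cores

The compounds below may be only part of what the source reports. "The series", "measured", "known", "first", "only" and "open" are said of these compounds alone.

Compound 1 `CCOC(=O)C1c2c[nH]nc2CCN1S(=O)(=O)c1ccc(Cl)cc1`: 1%
Compound 2 `O=S(=O)(c1ccc(Cl)cc1)N1CCc2n[nH]cc2C1c1cncnc1`: 50%
Compound 3 `O=S(=O)(c1ccc(Cl)cc1)N1Cc2c[nH]nc2CC1c1cncnc1`: 67%

In an ADME assay on microsomes from liver (Homo sapiens) for metabolic stability, using NADPH, with a stated time of 30 min, in the presence of a further agent that is not named here (a lower number here means that less of the compound is left, a higher number that more of the compound is left), compound 3 stands highest of the three measured compounds, with compound 2 next and compound 1 far behind. Compound 2 and compound 3 are built from the same atoms joined differently; the difference between the two cores is not broken down here. One change has been measured once: ethoxycarbonyl in place of pyrimidin-5-yl on a saturated ring carbon, which gave a number 49 percentage points lower from compound 2 to compound 1 (beyond the scatter). Compound 4 `CCOC(=O)C1Cc2n[nH]cc2CN1S(=O)(=O)c1ccc(Cl)cc1` carries the same change on the core of compound 3: ethoxycarbonyl in place of pyrimidin-5-yl on a saturated ring carbon. Within the data shown here, only one earlier step is available, and it was made on a different core, so the expectation is uncertain. The step expected here is a number 52 percentage points lower from compound 3 to compound 4 (beyond the scatter), resting on the earlier a number 49 percentage points lower from compound 2 to compound 1 (beyond the scatter). Compound 4 is thus estimated at 15%, with a likely range from 2% to 40%.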

Compound 4, percent of the compound remaining: 8%
Beside the measured number, compound 4's estimate is 7 percentage points above it; measured number inside the range.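

Putting ethoxycarbonyl in place of pyrimidin-5-yl gave a number 59 percentage points lower from compound 3 to compound 4 (beyond the scatter) in this assay. Set beside the earlier step, the change carried over between the two cores with no difference that can be told apart: the same change on two cores in this assay, a number 49 percentage points lower (beyond the scatter) from compound 2 to compound 1 and a number 59 percentage points lower (beyond the scatter) from compound 3 to compound 4, 10 percentage points apart, within the scatter of two such steps. Among these compounds, this rests on only two cores and one pair of groups, so it does not show that the step would hold on other cores, and it does not explain why the number falls.

The compounds shown leave open how other groups on that saturated ring carbon, such as a carboxylic acid, an amide or a phenyl ring, would fare. Going by these compounds, whether any of them would stand nearer to pyrimidin-5-yl or to ethoxycarbonyl also remains open.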